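A Stereocentre Flip in the Dicarboxypropyl Amide

The source may hold more compounds than are shown below. What is called first, only, known or untested is meant among the compounds shown, and "the series" means these compounds.

Values in a functional assay on PC-3 cells (Homo sapiens) for antiproliferative activity, read by MTT assay, with a stated time of 24 h; a higher number here means a weaker inhibitor, a lower number a stronger inhibitor:
- compound 1 `CCn1c(C(=O)NC2(CO)CC2)ccc1C(CC)(CC)c1ccc(OCS(=O)(=O)c2ccccc2)c(C)c1`: 3560 nM
- compound 2 `CCn1c(C(=O)N[C@@H](CCC(=O)O)C(=O)O)ccc1C(CC)(CC)c1ccc(OCS(=O)(=O)c2ccccc2)c(C)c1`: > 50000 nM

Compound 2 reports only > 50000 nM, which is a limit of the assay and not a number. Compound 3 `CCn1c(C(=O)N[C@H](CCC(=O)O)C(=O)O)ccc1C(CC)(CC)c1ccc(OCS(=O)(=O)c2ccccc2)c(C)c1` has the same atoms and bonds: the two compounds have the same atoms and bonds and differ only in configuration as drawn: 1 of 1 stereo elements differ; a stereocentre at a saturated chain carbon is drawn S in compound 2 and R in compound 3. Going by the values given here, the only measured step, an at least 14-fold higher number from compound 1 to compound 2 (1.14 log units; beyond the scatter), is large, but it replaces a group and is no test of configuration. Compound 3 keeps the 1,3-dicarboxypropyl group that entered in an at least 14-fold higher number from compound 1 to compound 2 (1.14 log units; beyond the scatter), so no step beyond the scatter is expected in this assay. The expected step is a number no higher from compound 2 to compound 3 (the limit leaves the size open). The estimate for compound 3 is 50000 nM, with an expected range of 20000 nM to 100000 nM.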

Compound 3, half-maximal inhibitory concentration: > 50000 nM
Compound 3 ended at the assay's limit; the forecaster's own chance of this, stated with the estimate: 65%; the middle value sits exactly at the limit.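

In this assay, the loss is not tied to the S centre of compound 2: the R centre of compound 3 carries it too, with an at least 14-fold higher number from compound 1 to compound 3 (1.14 log units; beyond the scatter). The value of compound 3, > 50000 nM, is a limit of the assay, so the step between the two configurations cannot be read: the limit of > 50000 nM in this assay, at which 2 of the 3 values shown sit. Going by these compounds alone, neither configuration at this stereocentre restores a measurable value, and configuration is the only variable in this pair: the fact that compounds 2 and 3 differ only in the configuration as drawn.

Still open, from the compounds shown here alone, is whether an amine or a methyl ester in place of the carboxylic acids of the 1,3-dicarboxypropyl group would bring a measurable value. Going by these compounds, how far compound 2 and compound 3 lie past the limit also remains unknown.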